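Fluoro to chloro beside the carboxy group: a second look

The source may hold more compounds than are shown below. What is called first, only, known or untested is meant among the compounds shown, and "the series" means these compounds.

Measured compounds in an assay for positive allosteric modulation of metabotropic glutamate receptor 3 (Rattus norvegicus); a lower number here means that less compound is needed, a higher number that more compound is needed for the effect:
- compound 1, `Cc1c(OC[C@@H](C)COc2ccc(F)c(C(=O)O)c2)ccc(C(=O)CC(C)(C)C)c1O`: 1180 nM
- compound 2, `Cc1c(OC[C@@H](C)COc2ccc(Cl)c(C(=O)O)c2)ccc(C(=O)CC(C)(C)C)c1O`: 2200 nM
- compound 3, `Cc1c(OC[C@@H](C)COc2ccc(C(=O)O)c(F)c2)ccc(C(=O)CC(C)(C)C)c1O`: 1090 nM

All three share the same core and differ only in the aryl ether attached to the oxygen on a saturated carbon. Compound 1 and compound 3 carry the same atoms joined differently; their difference is 4-carboxy-3-fluorophenyl in place of 3-carboxy-4-fluorophenyl on an oxygen on a saturated carbon, and in this assay it gave a 1.1-fold lower number from compound 1 to compound 3 (0.03 log units; within the scatter). Compound 2 relates to compound 1 by chloro in place of fluoro on an aromatic carbon, with a 1.9-fold higher number from compound 1 to compound 2 (0.27 log units; within the scatter). Compound 2 and compound 3 stand a 2.0-fold lower number from compound 2 to compound 3 (0.30 log units; within the scatter) apart. None of these steps leaves the scatter, so no ordering among the three is claimed.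

Compound 4, `Cc1c(OC[C@@H](C)COc2ccc(C(=O)O)c(Cl)c2)ccc(C(=O)CC(C)(C)C)c1O`, has not yet been measured in this assay. It relates to compound 3 by chloro in place of fluoro on an aromatic carbon. Among the compounds with values here, this is the same kind of change as the one from compound 1 to compound 2, but not the same: in compound 1 the exchanged atom sits para to a large group, in compound 3 it sits meta to a large group. Within the data shown here, only one prior example of this exchange exists, and it was within the scatter.

Among the measured compounds shown here, for compound 4 the step of a 1.7-fold higher number from compound 3 to compound 4 (0.22 log units; within the scatter) is expected, resting on the single precedent of a 1.9-fold higher number from compound 1 to compound 2 (0.27 log units; within the scatter). Compound 4 is thus estimated at 1800 nM, with a range from 900 nM to 3600 nM.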

Compound 4, half-maximal effective concentration: 860 nM
Beside the measured number, compound 4's estimate is 2.1-fold (0.32 log units) above it, outside the stated range (below it).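

Chloro in place of fluoro on an aromatic carbon, ortho to a carboxy group and meta to a large group, gives a 1.3-fold lower number from compound 3 to compound 4 (0.10 log units; within the scatter) in this assay, and the two examples of this exchange in the series cannot be told apart: the same change on two cores in this assay, a 1.9-fold higher number (0.27 log units; within the scatter) from compound 1 to compound 2 and a 1.3-fold lower number (0.10 log units; within the scatter) from compound 3 to compound 4, 2.4-fold (0.37 log units) apart, within the scatter of two such steps

This supports no claim that the exchange acts differently on the two cores, but two small steps, each within the scatter, do not show that it carries over unchanged to any other core in the series. The step beyond the scatter is a modest one between the two chloro compounds, a 2.6-fold lower number from compound 2 to compound 4 (0.41 log units; beyond the scatter), whereas a 1.4-fold lower number from compound 1 to compound 4 (0.14 log units; within the scatter) remains within the scatter, so the position of the groups on this ring has one modest step to its name and no general rule follows from it.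

The compounds shown leave open whether bromo or methyl at the same place would stay within the same narrow span of values. They also leave open whether a tetrazole in place of the carboxylic acid, or a shorter chain between the two oxygens, would change how the chloro and fluoro compounds compare.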